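Compound 4: one terminal chain swapped for a ring

A few compounds are considered here, and "the series" means these few. Any claim that something is new, unique, unknown or untested is made for them only; others in the source may bear on it.

- compound 1 `O=C(NCCCc1ccc(-c2ccc(CCCNC(=O)c3cc(F)cc(C(F)(F)F)c3)s2)s1)c1cc(F)cc(C(F)(F)F)c1`: "not determined" (no result reported)
- compound 2 `NCCCc1ccc(-c2ccc(-c3ccc(CCCN)s3)s2)s1`: > 200000 nM
- compound 3 `BrCCCc1ccc(-c2ccc(CCCBr)s2)s1`: "not determined" (no result reported)

These entries come from an ADME assay on MDCK cells (Canis lupus familiaris) for cytotoxicity, read by MTT assay, with a stated time of 2 days; on this read-out higher numbers stand for lower toxicity in this test and lower numbers for higher toxicity in this test. Compound 2 gives > 200000 nM, and this is a limit rather than a number. Compound 3 has no number of its own, as its entry of "not determined" (no result reported) shows, and so it gives no fixed starting point.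

The next compound is compound 4 `BrCCCc1ccc(-c2ccc(-c3cccs3)s2)s1`. The change is thiophen-2-yl in place of 3-bromopropyl on an aromatic carbon. No step beyond the usual scatter is expected in this assay, and no direction is expected either. For compound 4 the expected value is 100000 nM, with an estimated range from 25000 nM to 200000 nM.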

Compound 4, half-maximal cytotoxic concentration: 35300 nM
Compound 4: middle estimate off by 2.8-fold (0.45 log units), on the high side; the range from low to high includes it.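

Within the data shown here, compound 3 has no value of its own, so no step to compound 4 can be read. Whether thiophen-2-yl in place of 3-bromopropyl shifts the result in this assay stays open, and nothing shown accounts for the result of compound 4.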